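Methyl in place of methoxy: what compound 3 might show

The source may hold more compounds than are shown below. What is called first, only, known or untested is meant among the compounds shown, and "the series" means these compounds.

Compound 1 `COc1ccc(C2CC(c3ccc(Br)cc3)=NN2c2nc3ccc(S(N)(=O)=O)cc3s2)cc1` was tested in a functional assay on the whole organism (strain Wistar) for inhibition, with Rattus norvegicus as the target, read by paw edema, with stated times of 1 h and 5 h, at a dose of 20 mg/kg by the oral route (on this read-out lower numbers stand for less inhibition and higher numbers for more inhibition at the one dose given (going by the name of the read-out)), and gave 14%, the lower of the two numbers measured. Going by the values given here, the only other measured compound, compound 2 `COc1ccc(C2CC(c3ccc(Cl)cc3)=NN2c2nc3ccc(S(N)(=O)=O)cc3s2)cc1`, gave 67.7% in this assay, and the step of a number 53.7 percentage points higher from compound 1 to compound 2 (beyond the scatter) came from chloro in place of bromo on an aromatic carbon. The unmeasured compound 3 `Cc1ccc(C2CC(c3ccc(Br)cc3)=NN2c2nc3ccc(S(N)(=O)=O)cc3s2)cc1` differs from compound 1 in a different place: methyl in place of methoxy on an aromatic carbon. Among the compounds with values here, no measured step touches this change, since the one step on record concerns the halogen and not the methoxy group, so it gives no guide to the size or direction of the effect here. In the absence of a bearing step, compound 3 is expected to stay close to compound 1, with the change a number 4 percentage points higher from compound 1 to compound 3 (within the scatter) estimated to lie within the scatter. The estimated value for compound 3 is 18%, in the range 3% to 50%.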

Compound 3, a percentage reported as inhibition, in the whole organism at one dose (the size of the read-out at that dose, not a potency): 14%
The estimate for compound 3 lay 4 percentage points above the measured number; measured number inside the range.
By their numbers in this assay, from the lowest: compounds 1 and 3 (each within the scatter of the next); then compound 2.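

In this assay, going by these compounds alone, the exchange of 4-methoxyphenyl for 4-methylphenyl gave no change at the digits printed from compound 1 to compound 3 (within the scatter), the first reading at this position, as the earlier step lay at the halogen. With the bromo group in place, the oxygen of the methoxy group and its hydrogen-bond acceptor thus made no difference that this read-out could register, in contrast to the halogen exchange, which gave a number 53.7 percentage points higher from compound 1 to compound 2 (beyond the scatter). No measurement on hand accounts for this outcome.

The compounds shown leave open whether the same exchange would also make no difference with the chloro group in place, where the number starts much higher. They also leave open how an amine, a carboxylic acid or a longer chain such as ethoxy would read at this position on the aromatic ring.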